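This account rests on a few compounds, and the source may have more. Where it says the series, first, only, none or still open, it means among the compounds named here.

Compound 3 `O=C(Nc1ccc(OCc2nc3ccccc3s2)cc1)Nc1ccc(Cl)c(Cl)c1` gives 570 nM in an assay on isolated protein for inhibition of Polyunsaturated fatty acid 5-lipoxygenase (Homo sapiens), read by HPLC, with a stated time of 10 min (on this read-out lower numbers stand for stronger inhibition and higher numbers for weaker inhibition), the highest of the three numbers. Compound 2 `O=C(Nc1ccccc1)Nc1ccc(OCc2nc3ccccc3s2)cc1` gives 420 nM in this assay, within the scatter of compound 3, while compound 1 `Cc1cc(OCc2nc3ccccc3s2)ccc1NC(=O)Nc1cccc(Cl)c1` gives 160 nM, a gap that lies beyond the scatter. Compound 4 `O=C(Nc1ccc(OCc2nc3ccccc3s2)cc1)Nc1cccc(Cl)c1` differs from compound 3 by hydrogen in place of chloro on an aromatic carbon. Among the measured compounds shown here, the one measured step that bears on this change is a 1.4-fold higher number from compound 2 to compound 3 (0.13 log units; within the scatter), which shows that chlorination of the phenyl on the amide-type nitrogen left the number within the scatter. Removing one of those two chloro groups is therefore expected to move the number little, a 1.5-fold lower number from compound 3 to compound 4 (0.18 log units; within the scatter), though the low number of compound 1 leaves room for a somewhat lower value. Compound 4 is estimated at 380 nM, between 150 nM and 900 nM.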

Compound 4, half-maximal inhibitory concentration: 170 nM
Estimate against measurement, compound 4: 2.2-fold (0.35 log units) above; low and high end bracket the measured number.
By their numbers in this assay, from the lowest: compounds 1 and 4 (each within the scatter of the next); then compounds 2 and 3 (each within the scatter of the next).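

In this assay the step that removes the chloro group para to a large group is a 3.4-fold lower number from compound 3 to compound 4 (0.53 log units; beyond the scatter) and the step that adds the remaining chloro group to the phenyl is a 2.5-fold lower number from compound 2 to compound 4 (0.39 log units; beyond the scatter) so among these three compounds the number does not follow the count of chloro groups: one gives a lower number than none or two. The step for hydrogen in place of methyl is a 1.1-fold higher number from compound 1 to compound 4 (0.03 log units; within the scatter) so the low number of compound 1 is matched without its methyl group. No measurement shown explains this pattern.

From the compounds shown here alone, it remains open whether a chloro group para to a large group, without the other chloro group, would match compound 3. Also open, going by these compounds, is how fluoro, methoxy or a carboxylic acid would read in place of the remaining chloro group.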